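Propoxycarbonyl Gives Way to Isopropylsulfonyl

This account rests on a few compounds, and the source may have more. Where it says the series, first, only, none or still open, it means among the compounds named here.

In a functional assay on CHO-K1 cells with Glucose-dependent insulinotropic receptor (Homo sapiens) as the target, read by a luciferase reporter, with a stated time of 5 h (on this read-out lower numbers stand for smaller maximal responses and higher numbers for larger maximal responses), compound 2 `CCCOC(=O)N1CCC(Oc2ncnc3c2CCN3c2ccc(S(C)(=O)=O)cc2F)CC1` gives 111%, the higher of the two measured values. Compound 1 `CC(C)OC(=O)N1CCC(Oc2ncnc3c2CCN3c2ccc(-c3nccs3)cc2F)CC1` gives 74% in this assay, a gap beyond the usual scatter. Compound 3 `CC(C)S(=O)(=O)N1CCC(Oc2ncnc3c2CCN3c2ccc(S(C)(=O)=O)cc2F)CC1` is not yet measured and differs from compound 2 in one place: isopropylsulfonyl in place of propoxycarbonyl on an amine nitrogen in a ring. Going by the values given here, no measured pair shows a change of this kind, so its direction is uncertain. Compound 3 is estimated at 95%, within a range from 70% to 120%. The expected step, a number 16 percentage points lower from compound 2 to compound 3 (beyond the scatter), is a small decrease that may still lie within the scatter.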

Compound 3, largest response reached (reported as percent of maximum), in percent of the reference or control that the assay uses: 62%
Beside the measured number, compound 3's estimate is 33 percentage points above it; the measured number lies below the stated range.
By their numbers in this assay, from the lowest: compound 3; then compound 1; then compound 2.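

In this assay, the group on this amine nitrogen in a ring clearly matters: isopropylsulfonyl in place of propoxycarbonyl gives a large drop, a number 49 percentage points lower from compound 2 to compound 3 (beyond the scatter). The two groups have equal counts of heavy atoms and hydrogen-bond acceptors, so these counts alone do not settle the maximal response here. No measurement available explains the loss.

The compounds shown leave open whether the sulfonyl link or the branched chain goes with the drop. A propylsulfonyl group on the same nitrogen would help separate the two.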